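A few compounds are considered here, and "the series" means these few. Any claim that something is new, unique, unknown or untested is made for them only; others in the source may bear on it.

Values measured in an ADME assay on LLC-PK1 cells (Sus scrofa) for permeability (a higher number here means that the compound crosses the layer faster, a lower number that the compound crosses the layer more slowly), so far
- compound 1 `COC[C@]12C[C@H]1[C@@](C)(c1cc(NC(=O)c3ccc(Cl)cn3)cc(F)c1F)N=C(N)S2` gives 13 10^-6 cm/s
- compound 2 `C#CCOc1ccc(C(=O)Nc2cc(F)c(F)c([C@@]3(C)N=C(N)S[C@@]4(COC)C[C@H]43)c2)nc1` gives 14 10^-6 cm/s
- compound 3 `COC[C@]12C[C@H]1[C@@](C)(c1cc(NC(=O)c3cnc(OCC(F)(F)F)cn3)cc(F)c1F)N=C(N)S2` gives 25 10^-6 cm/s

Compound 3 lies within the scatter of both other compounds, so the three numbers set no order. Compound 4 `CCCOc1cnc(C(=O)Nc2cc(F)c(F)c([C@@]3(C)N=C(N)S[C@@]4(COC)C[C@H]43)c2)cn1` differs from compound 3 by ethyl in place of trifluoromethyl on a saturated chain carbon bound to an oxygen on an aromatic ring in one place: ethyl in place of trifluoromethyl on a saturated chain carbon bound to an oxygen on an aromatic ring, which also reads 2,2,2-trifluoroethoxy to propoxy. For the measured compounds named here, no measured step makes this change. Going by the values given here, the only measured step, a 1.1-fold higher number from compound 1 to compound 2 (0.03 log units; within the scatter) with propargyloxy in place of chloro on an aromatic carbon, lies within the scatter and is a different change, so it gives weak guidance. No shift beyond the scatter is therefore expected in this assay and no direction is favoured. The estimated step is a 1.1-fold lower number from compound 3 to compound 4 (0.06 log units; within the scatter) and is expected to stay within the scatter. For compound 4 the estimate is 22 10^-6 cm/s with an expected range of 12 10^-6 cm/s to 38 10^-6 cm/s in this read-out.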

Compound 4, apparent permeability: 18 10^-6 cm/s
For compound 4 the middle estimate is 1.2-fold (0.09 log units) above the measured one, and the stated range covers the measured number.
By their numbers in this assay, from the lowest: compounds 1, 2, 4 and 3 (each within the scatter of the next).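

In this assay, ethyl in place of trifluoromethyl on a saturated chain carbon bound to an oxygen on an aromatic ring stays within the scatter, with a 1.4-fold lower number from compound 3 to compound 4 (0.14 log units; within the scatter), so this position tolerates the 2,2,2-trifluoroethoxy to propoxy change in this read-out. Exchanging the whole group on the carbonyl carbon for 5-propoxypyrazin-2-yl also stays within the scatter, with a 1.3-fold higher number from compound 2 to compound 4 (0.11 log units; within the scatter) and a 1.4-fold higher number from compound 1 to compound 4 (0.14 log units; within the scatter). No available evidence gives a cause for these readings.

As far as these compounds go, whether an amine, a carboxylic acid or a chain longer than propyl in this place would move the number beyond the scatter remains open.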